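From 2-hydroxyethyl to 2-sulfanylethyl on the shared core

The source may report more compounds than this note shows. Statements on the series, on what has been measured and on what is new or still open speak of the compounds shown alone.

In a functional assay on the whole organism with Rattus norvegicus as the target (a lower number here means that less compound is needed, a higher number that more compound is needed for the effect), compound 1 `COC(=O)Cn1c(=N)sc2cc(OC(F)(F)F)ccc21` gives > 10 mg/kg as a limit of the assay and not a number. Compound 2 `CN(C)S(=O)(=O)CCn1c(=N)sc2cc(OC(F)(F)F)ccc21` gives > 10 mg/kg as a limit too. Compound 3 `N=c1sc2cc(OC(F)(F)F)ccc2n1CCO` gives 8 mg/kg and is the only one of the three with a number.

The next change, to compound 4 `N=c1sc2cc(OC(F)(F)F)ccc2n1CCS`, is sulfanyl in place of hydroxy on a saturated chain carbon, two bonds along the chain from an aromatic nitrogen and places sulfanyl in place of hydroxy on a saturated chain carbon, two bonds along the chain from an aromatic nitrogen.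

Going by the values given here, no measured step makes this exchange. The nearest are an at least 1.2-fold lower number from compound 1 to compound 3 (0.09 log units; that floor lies within the scatter) and an at least 1.2-fold lower number from compound 2 to compound 3 (0.09 log units; that floor lies within the scatter) and both rest on limits, so they give only floors within the scatter. The step that the two limits leave unreadable from compound 1 to compound 2 adds nothing on size. These steps show how compound 3 relates to its neighbours but not what sulfur does in place of oxygen.

With no guide to direction, the expectation is no change at the digits printed from compound 3 to compound 4 (within the scatter) and no shift beyond the scatter is expected. Compound 4 is estimated at 8 mg/kg with an expected range from 3 mg/kg to 20 mg/kg. An outcome that is only a limit remains quite possible.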

Compound 4, dose for half-maximal effect: 2 mg/kg
For compound 4 the middle estimate is 4.0-fold (0.60 log units) above the measured one; the whole stated range lies above it.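

In this assay, going by these compounds alone, sulfanyl in place of hydroxy on a saturated chain carbon, two bonds along the chain from an aromatic nitrogen, gives the first step with a readable size beyond the scatter: a 4.0-fold lower number from compound 3 to compound 4 (0.60 log units; beyond the scatter). The 2-sulfanylethyl group also stands clear of the two other side chains, with an at least 5.0-fold lower number from compound 2 to compound 4 (0.69 log units; beyond the scatter) and an at least 5.0-fold lower number from compound 1 to compound 4 (0.69 log units; beyond the scatter), a separation that the 2-hydroxyethyl group of compound 3 did not establish. Those two steps are only floors, and the step from compound 1 to compound 2 cannot be read, because compound 1 and compound 2 both stand at a limit of the assay and not at a number: the limit of > 10 mg/kg in this assay, at which 2 of the 4 values shown sit.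

As far as these compounds go, it stays open whether an amine or a methyl thioether at the same place would match the sulfanyl group, and whether a longer chain carrying sulfanyl would keep the step. From the compounds shown here alone, the exchange of hydroxy for sulfanyl rests on a single pair on the shared core, so its size with other substituents on that core is also open.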